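Chain extension at the ring nitrogen of the shared core

The compounds below may be only part of what the source reports. "The series", "measured", "known", "first", "only" and "open" are said of these compounds alone.

Compound 3 `CCCc1nc(C)c2c(C)nn(CC)c(=O)n12` is known in a functional assay for inhibition, with Homo sapiens as the target (on this read-out lower numbers stand for stronger inhibition and higher numbers for weaker inhibition), only as a limit: compound 3 gives > 48000 nM. Compound 1 `CCCc1nc(C)c2c(C)nn(C)c(=O)n12` sits at the same limit in this assay, with compound 1 at > 48000 nM. Going by the values given here, compound 2 `Oc1nnc(Br)c2c(Br)nc(Br)n12`, built on a different core, is the only member with a number; in this assay compound 2 gives 27000 nM. Among the compounds with values here, the one step that joins two measured compounds, a step that the two limits leave unreadable from compound 1 to compound 3, is unreadable because the limit of > 48000 nM in this assay, at which 2 of the 3 values shown sit, hides both ends.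

Compound 4 `CCCc1nc(C)c2c(C)nn(CCC)c(=O)n12` differs from compound 3 by methyl in place of hydrogen on a saturated chain carbon, two bonds along the chain from an aromatic nitrogen; read one bond further out, the change is ethyl to propyl. Within the data shown here, no measured step shows the effect of such a lengthening on this core, so the expectation rests on the position of compound 3 at the limit. The step from compound 3 to compound 4 is expected to be a step that the limit leaves unreadable from compound 3 to compound 4, that is, nothing that would be readable. Compound 4 is therefore estimated at 60000 nM, with a range from 20000 nM to 200000 nM, and most likely reported again only as a limit.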

Compound 4, half-maximal inhibitory concentration: > 48000 nM
Compound 4 gave a limit, no number; the forecaster's own chance of this, stated with the estimate: 85%; the middle value does not contradict the limit.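

No new step can be read among compound 1, compound 3 and compound 4, because both ends of each step are hidden by one limit: the limit of > 48000 nM in this assay, at which 3 of the 4 values shown sit.

The compounds shown leave open whether in this assay any chain on the ring nitrogen of the shared core gives a number rather than a limit.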